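Notes on the step from compound 3 to compound 4

A few compounds are considered here, and "the series" means these few. Any claim that something is new, unique, unknown or untested is made for them only; others in the source may bear on it.

Three compounds of the series have numbers in a functional assay on MCF7 cells (Homo sapiens) for cytotoxicity, read by MTT assay, with a stated time of 96 h; a lower number here means a stronger inhibitor, a higher number a weaker inhibitor. Compound 1 `COc1cc(C(=O)c2cn(-c3ccccc3[N+](=O)[O-])cc2-c2ccccc2)cc(OC)c1OC` gives 5000 nM in this assay, and compound 2 `COc1cc(C(=O)c2cn(-c3ccc([N+](=O)[O-])cc3)cc2-c2ccccc2)cc(OC)c1OC` gives 4000 nM. For the measured compounds named here, the single one-place step among the measured compounds is a 1.3-fold lower number from compound 1 to compound 2 (0.10 log units; within the scatter), a change on the aromatic nitrogen only. Compound 3 `COc1cc(C(=O)c2cn(-c3ccccc3)cc2-c2ccccc2Cl)cc(OC)c1OC` gives 76 nM, the lowest of the three numbers, and its gaps to compound 2 and to compound 1 both lie well beyond the scatter.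

Compound 4 `COc1cc(C(=O)c2cn(-c3ccccc3)cc2/C=C/c2ccccc2)cc(OC)c1OC` has not been measured in this assay. Its difference from compound 3 is 2-phenylethenyl in place of 2-chlorophenyl on an aromatic carbon. Going by the values given here, no measured step touches this position: the one step that exists concerns the group on the aromatic nitrogen and says nothing about exchanging 2-chlorophenyl for 2-phenylethenyl on the aromatic carbon. The values of compounds 1, 2 and 3 show only that the series spans a wide range in this assay, so the step is judged with little support. A higher number than compound 3 is expected, with a broad range to reflect the missing precedent; the expected step is a 5.3-fold higher number from compound 3 to compound 4 (0.72 log units; beyond the scatter). Compound 4 is accordingly estimated at 400 nM, between 60 nM and 3000 nM.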

Compound 4, half-maximal inhibitory concentration: 2200 nM
Compound 4: the middle estimate sits 5.5-fold (0.74 log units) below what was measured; the range from low to high includes it.
By their numbers in this assay, from the lowest: compound 3; then compounds 4, 2 and 1 (each within the scatter of the next, the first and the last beyond it).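

The aromatic carbon two ring bonds from the ring nitrogen now has its first measured exchange: in this assay, placing 2-phenylethenyl where 2-chlorophenyl stood gives a 29-fold higher number from compound 3 to compound 4 (1.46 log units; beyond the scatter). This position therefore does not treat the two groups alike, although each brings one six-membered aromatic ring of carbon only and neither has a hydrogen-bond donor or acceptor, so these shared counts do not settle the number here. The pair differs in the chlorine, the double bond outside aromatic rings and the heavy-atom count, and no measurement at hand assigns the step to any one of these.

The compounds shown leave open how a saturated 2-phenylethyl group, which would keep the carbon chain without the double bond, or a 2-aminophenyl group, which would put an amine where the chlorine stands, would compare at this carbon in this assay. Also open, on these data alone, is whether the size of this step would hold with a nitrophenyl group rather than phenyl on the aromatic nitrogen.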